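A few compounds are considered here, and "the series" means these few. Any claim that something is new, unique, unknown or untested is made for them only; others in the source may bear on it.

Going by the values given here, in an assay on liver (Sus scrofa) for inhibition of glucose-6-phosphatase catalytic subunit 1 (Homo sapiens), using microsomes (on this read-out higher numbers stand for weaker inhibition and lower numbers for stronger inhibition), compound 3 `COc1ccc(/C=N/N(Cc2ccccc2)Cc2ccccc2)cc1` gives 220 nM, the lowest of the three numbers measured so far. Compound 1 `C(=N/N(Cc1ccccc1)Cc1ccccc1)\c1ccccc1` gives 1500 nM, and compound 2 `c1ccc(CN(Cc2ccccc2)/N=C2\CCCc3ccccc32)cc1` gives 25000 nM, the highest of the set. The change toward compound 4 `Clc1ccc(/C=N/N(Cc2ccccc2)Cc2ccccc2)cc1` is chloro in place of methoxy on an aromatic carbon. Among the compounds with values here, no measured pair covers this exchange directly. Within the data shown here, the only single step in the set, a 6.8-fold lower number from compound 1 to compound 3 (0.83 log units; beyond the scatter), shows that placing methoxy on an aromatic carbon of the shared core lowers the number beyond the scatter, so a substituent there is clearly tolerated or helpful. Whether chloro holds onto that gain, or gives back part of it toward the unsubstituted compound 1, is not shown by any pair here. The expectation for compound 4 is a number lying between those of compound 1 and compound 3, with a lean toward compound 3. For compound 4 a step of a 2.0-fold higher number from compound 3 to compound 4 (0.31 log units; beyond the scatter) is expected. Compound 4 is therefore estimated in this assay at 450 nM, with a range from 130 nM to 1500 nM.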

Compound 4, half-maximal inhibitory concentration: 240 nM
Estimate against measurement, compound 4: 1.9-fold (0.27 log units) above, within the range that was stated.
By their numbers in this assay, from the lowest: compounds 3 and 4 (each within the scatter of the next); then compound 1; then compound 2.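

In this assay the change from 4-methoxyphenyl to 4-chlorophenyl gives a 1.1-fold higher number from compound 3 to compound 4 (0.04 log units; within the scatter) and so separates the two groups by no more than the scatter. Set on the unsubstituted compound, chloro gives a 6.3-fold lower number from compound 1 to compound 4 (0.80 log units; beyond the scatter) and methoxy gives a 6.8-fold lower number from compound 1 to compound 3 (0.83 log units; beyond the scatter) in the earlier step, so the lower number at this position appears with both groups and does not require the oxygen or the hydrogen-bond acceptor that methoxy carries. No measurement here bears on why the two groups match.

Going by these compounds, two substituents cannot define what this position accepts, so it remains open whether an amine, a carboxylic acid or a longer chain would keep the lower number. On these data alone, whether chloro or methoxy would do the same elsewhere on this aromatic ring also remains open.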